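Aryl Substituent Series: Fluoro in Place of Isopropyl

The source may hold more compounds than are shown below. What is called first, only, known or untested is meant among the compounds shown, and "the series" means these compounds.

Of the compounds shown here, three have been measured in an assay on isolated protein for agonist activity at Free fatty acid receptor 1 (Homo sapiens); a lower number here means that less compound is needed, a higher number that more compound is needed for the effect. Compound 1 `CC#CC(CC(=O)O)c1ccc(OCc2ccc3nc(-c4ccc(CC)cc4)cn3c2)cc1` gives 496 nM, compound 2 `CC#CC(CC(=O)O)c1ccc(OCc2ccc3nc(-c4ccc(C(F)(F)F)cc4)cn3c2)cc1` gives 558 nM, and compound 3 `CC#CC(CC(=O)O)c1ccc(OCc2ccc3nc(-c4ccc(C(C)C)cc4)cn3c2)cc1` gives 528 nM. Compound 3 sits within the scatter of both neighbours: the step of a 1.1-fold lower number from compound 2 to compound 3 (0.02 log units; within the scatter) is its nearest, the step of a 1.1-fold higher number from compound 1 to compound 3 (0.03 log units; within the scatter) its furthest, and neither amounts to a real difference.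

Compound 4 `CC#CC(CC(=O)O)c1ccc(OCc2ccc3nc(-c4ccc(F)cc4)cn3c2)cc1` is not yet measured. Relative to compound 3 the change is fluoro in place of isopropyl on an aromatic carbon.

Among the measured compounds shown here, the steps that bear on this change are those that exchange the group on the same aromatic carbon: a 1.1-fold higher number from compound 1 to compound 2 (0.05 log units; within the scatter) and a 1.1-fold lower number from compound 2 to compound 3 (0.02 log units; within the scatter). Ethyl, trifluoromethyl and isopropyl at this place all return numbers within the scatter of one another, so the three measured compounds give no sign that the substituent on this ring moves the read-out. Fluoro is a smaller group than any of these three, but no measured step tests a group of that size, and the expectation for this assay is therefore no step beyond the scatter. The expected step is a 1.1-fold higher number from compound 3 to compound 4 (0.03 log units; within the scatter). Compound 4 is accordingly estimated at 560 nM, with a range from 250 nM to 1300 nM.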

Compound 4, half-maximal effective concentration: 623 nM
For compound 4 the middle estimate is 1.1-fold (0.05 log units) below the measured one; the measured number falls inside the stated range.
By their numbers in this assay, from the lowest: compounds 1, 3, 2 and 4 (each within the scatter of the next).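

In this assay, among the compounds shown here, the change from 4-isopropylphenyl to 4-fluorophenyl gives a 1.2-fold higher number from compound 3 to compound 4 (0.07 log units; within the scatter) and so extends the flat picture to an entering group of a single heavy atom, where the earlier compounds only covered groups larger than fluoro. For the compounds shown here, the exchanges of the other two groups at this aromatic carbon agree with it, with a 1.1-fold higher number from compound 2 to compound 4 (0.05 log units; within the scatter) for fluoro in place of trifluoromethyl and a 1.3-fold higher number from compound 1 to compound 4 (0.10 log units; within the scatter) for fluoro in place of ethyl, so ethyl, trifluoromethyl, isopropyl and fluoro cannot be separated at this place and no compound among the four goes against that reading. Nothing available on these compounds offers a measured explanation for this flat read-out.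

The compounds shown leave open whether an amine, a carboxylic acid or a longer chain such as hexyl on this same carbon would also stay within the scatter, as all four groups here carry no hydrogen-bond donor, no hydrogen-bond acceptor and no net charge. Also open, as far as these compounds go, is whether these four groups would remain indistinguishable if the shared core were changed elsewhere.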